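Swapping a sulfonyloxy group for an aminohexyl chain

This account rests on a few compounds, and the source may have more. Where it says the series, first, only, none or still open, it means among the compounds named here.

Compound 1 `NCCCNc1c(C(=O)NCc2ccc(F)cc2)nc(Br)c2cccnc12` gives > 20000 nM as a limit
Compound 2 `Cc1ccc(S(=O)(=O)Oc2c(C(=O)NCc3ccc(F)cc3)nc(Br)c3cccnc23)cc1` gives > 20000 nM as a limit

In a functional assay on HCT-116 cells (Homo sapiens) for cytotoxicity, read by MTT assay, with a stated time of 72 h (on this read-out lower numbers stand for stronger inhibition and higher numbers for weaker inhibition), compound 2 gives only a limit and no number: > 20000 nM. Compound 3 `NCCCCCCNc1c(C(=O)NCc2ccc(F)cc2)nc(Br)c2cccnc12` differs from it as follows: (6-aminohexyl)amino in place of ((4-methylphenyl)sulfonyl)oxy on an aromatic carbon. Among the compounds with values here, the one measured step, a step that the two limits leave unreadable from compound 1 to compound 2, has no readable size, and the limit of > 20000 nM in this assay, at which 2 of the 2 values shown sit, describes both compounds. Neither compound offers a number to scale from, so no clear step is expected in this assay, though any shift would be expected towards stronger inhibition. The expected step is a number no higher from compound 2 to compound 3 (the limit leaves the size open). Compound 3 is estimated as 20000 nM, with an expected range of 6000 nM to 60000 nM.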

Compound 3, half-maximal inhibitory concentration: 7000 nM
For compound 3 the middle estimate is 2.9-fold (0.46 log units) above the measured one; the range from low to high includes it.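

In this assay, within the data shown here, the (6-aminohexyl)amino group gives the first readable number at this position, with an at least 2.8-fold lower number from compound 2 to compound 3 (0.45 log units; beyond the scatter). Between the two aminoalkylamino compounds, a change in chain length alone gives an at least 2.8-fold lower number from compound 1 to compound 3 (0.45 log units; beyond the scatter). Both sizes are minimums, since the starting compounds give only a limit: the limit of > 20000 nM in this assay, at which 2 of the 3 values shown sit.

On these data alone, how the number moves with a chain of intermediate length, such as 4-aminobutyl, or with a longer chain stays open. So does whether the terminal amine is needed, which a terminal hydroxyl on the same hexyl chain would show.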